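Adding a dimethylamino group to the core of compound 1

A few compounds are considered here, and "the series" means these few. Any claim that something is new, unique, unknown or untested is made for them only; others in the source may bear on it.

Compound 1 `Fc1ccc(-c2nn3ccc(Cl)cc3c2-c2ccnc(NC3CCCC3)n2)cc1` gives > 40000 nM in an ADME assay on Vero cells (Chlorocebus sabaeus) for cytotoxicity (on this read-out higher numbers stand for lower toxicity in this test and lower numbers for higher toxicity in this test), a limit of the assay.
Compound 2 `Nc1ccn2nc(-c3ccc(F)cc3)c(-c3ccnc(NC4CCCC4)n3)c2c1` gives 20000 nM in this assay.
Compound 3 `CC(C)Nc1ccn2nc(-c3ccc(F)cc3)c(-c3ccnc(NC4CCCC4)n3)c2c1` gives > 40000 nM in this assay, a limit of the assay.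

Compound 1 therefore stands at the limit of > 40000 nM in this assay, at which 2 of the 3 values shown sit, and no exact number is known for it. Compound 4 `CN(C)c1cc(Cl)cc2c(-c3ccnc(NC4CCCC4)n3)c(-c3ccc(F)cc3)nn12` differs from compound 1 by dimethylamino in place of hydrogen on an aromatic carbon, while the chloro group of compound 1 stays. The measured steps all concern the carbon that carries that chloro group: an at least 2.0-fold lower number from compound 1 to compound 2 (0.30 log units; that floor lies within the scatter), an at least 2.0-fold higher number from compound 2 to compound 3 (0.30 log units; that floor lies within the scatter) and a step that the two limits leave unreadable from compound 1 to compound 3. None of them touches the position changed here, and two of the three values sit at the limit, so no step beyond the scatter is expected in this assay. Compound 4 is estimated at 35000 nM, within 15000 nM to 80000 nM, which would mean an expected at least 1.1-fold lower number from compound 1 to compound 4 (0.05 log units; that floor lies within the scatter).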

Compound 4, half-maximal cytotoxic concentration: > 40000 nM
Compound 4: only a limit was reported; the forecaster's own chance of this, stated with the estimate: 55%; at least 1.1-fold (0.05 log units) between middle value and limit.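

Compound 1 and compound 4 both stand at a limit of this assay, so no step between them can be read: the limit of > 40000 nM in this assay, at which 3 of the 4 values shown sit.

The compounds shown leave open whether dimethylamino in place of hydrogen changes this read-out at all.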